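Sulfamoyl for ethoxy on a benzylamide series

A few compounds are considered here, and "the series" means these few. Any claim that something is new, unique, unknown or untested is made for them only; others in the source may bear on it.

Measured so far in an assay on HeLa cells with Bile acid receptor (Homo sapiens) as the target, read by a luciferase reporter, with a stated time of 24 h; a lower number here means that less compound is needed, a higher number that more compound is needed for the effect:
compound 1, `C[S+]([O-])c1ccc(CNC(=O)c2ccc(C(C)(C)C)cc2)cc1`, 1300 nM
compound 2, `CC(C)(C)c1ccc(C(=O)NCc2ccc(OC(F)(F)F)cc2)cc1`, 160 nM
compound 3, `CCOc1ccc(CNC(=O)c2ccc(C(C)(C)C)cc2)cc1`, 160 nM

Compound 3 stands level with compound 2 at the digits shown, the two of them sharing the lowest number of the three; compound 1 sits far above them, as the step of an 8.1-fold lower number from compound 1 to compound 3 (0.91 log units; beyond the scatter) shows. All three compounds share one core and differ only in the group on the aromatic carbon of the second ring.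

The change now considered is sulfamoyl in place of ethoxy on an aromatic carbon, giving compound 4, `CC(C)(C)c1ccc(C(=O)NCc2ccc(S(N)(=O)=O)cc2)cc1`. Within the data shown here, two measured steps bear on it. The step of an 8.1-fold lower number from compound 1 to compound 3 (0.91 log units; beyond the scatter) and the step of an 8.1-fold lower number from compound 1 to compound 2 (0.91 log units; beyond the scatter) both show that swapping the group of 1 carbon, 1 oxygen and 1 sulfur of compound 1 for an oxygen-linked group lowered the number clearly. The step of no change at the digits printed from compound 2 to compound 3 (within the scatter) shows that ethyl or trifluoromethyl on that oxygen made no difference beyond the scatter. Sulfamoyl, like the departing group of compound 1, contains sulfur and two oxygens with a hydrogen-bond donor, and no oxygen-linked chain, so the number is expected to move back up toward that of compound 1, in this assay.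

Compound 4 is therefore estimated at 1000 nM, within 300 nM to 3500 nM, an expected step of a 6.3-fold higher number from compound 3 to compound 4 (0.80 log units; beyond the scatter).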

Compound 4, half-maximal effective concentration: 1400 nM
The estimate for compound 4 lay 1.4-fold (0.15 log units) below the measured number; low and high end bracket the measured number.
By their numbers in this assay, from the lowest: compounds 2 and 3 (each within the scatter of the next); then compounds 1 and 4 (each within the scatter of the next).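

In this assay, sulfamoyl on this aromatic carbon sits clearly apart from both oxygen-linked groups, with an 8.8-fold higher number from compound 3 to compound 4 (0.94 log units; beyond the scatter) and an 8.8-fold higher number from compound 2 to compound 4 (0.94 log units; beyond the scatter). Against the sulfur-bearing group of compound 1 it shows a 1.1-fold higher number from compound 1 to compound 4 (0.03 log units; within the scatter), so among these four compounds, two different sulfur-bearing groups share the high end while ethoxy and trifluoromethoxy share the low end, a split that the first three compounds could only hint at with a single sulfur-bearing example. No measurement is available that explains this split.

The compounds shown leave open whether the high numbers go with the sulfur atom itself or with the oxygens attached to it; a methylthio group, which carries sulfur without those oxygens, and a methylsulfonyl group, which keeps them without the nitrogen of sulfamoyl, would help separate these readings. They also leave open how far the low numbers extend among oxygen-linked groups, for example to a longer chain such as butoxy, or whether a group with neither sulfur nor an oxygen link, such as an amine or a carboxylic acid, falls at either end.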